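Branching the amine chain on the chloro compound

The source may hold more compounds than are shown below. What is called first, only, known or untested is meant among the compounds shown, and "the series" means these compounds.

Measured in a functional assay (aorta) with Rattus norvegicus as the target; a higher number here means that more compound is needed for the effect, a lower number that less compound is needed:
- compound 1 `CCNC1=NS(=O)(=O)c2cc(F)ccc2N1`: > 300 uM, a limit of the assay
- compound 2 `CCC(C)NC1=NS(=O)(=O)c2cc(F)ccc2N1`: 39.2 uM
- compound 3 `CCNC1=NS(=O)(=O)c2cc(Cl)ccc2N1`: 39.9 uM

Compound 3 at 39.9 uM lies within the scatter of compound 2, so the two numbers cannot be told apart. The next candidate is compound 4 `CC(C)C(C)NC1=NS(=O)(=O)c2cc(Cl)ccc2N1`, which carries isopropyl in place of hydrogen on a saturated chain carbon bound to an amine nitrogen and a saturated chain carbon. This turns ethyl into 1,2-dimethylpropyl.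

Among the measured compounds shown here, the closest precedent is an at least 7.6-fold lower number from compound 1 to compound 2 (0.88 log units; beyond the scatter), where ethyl entered at the same kind of carbon. The chloro for fluoro exchange, an at least 7.5-fold lower number from compound 1 to compound 3 (0.87 log units; beyond the scatter), is already present in compound 3. Both sizes rest on (the limit of > 300 uM in this assay, at which 1 of the 3 values shown sits), so they are bounds only. For the measured compounds named here, no measured compound combines chloro with a branched chain, so additivity is untested.

In this assay, a modest shift to a lower number is expected, given the precedent of an at least 7.6-fold lower number from compound 1 to compound 2 (0.88 log units; beyond the scatter). The expected step is a 5.0-fold lower number from compound 3 to compound 4 (0.70 log units; beyond the scatter). For compound 4 the estimate is 8 uM, with an expected range of 1.5 uM to 35 uM.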

Compound 4, concentration for half-maximal effect: 1.2 uM
Compound 4: the middle estimate sits 6.7-fold (0.82 log units) above what was measured; the whole stated range lies above it.
By their numbers in this assay, from the lowest: compound 4; then compounds 2 and 3 (each within the scatter of the next). At a limit, above all of these: compound 1.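

In this assay, the saturated chain carbon bound to an amine nitrogen and a saturated chain carbon accepts isopropyl in place of hydrogen on the chloro compound, and the number falls sharply: a 33-fold lower number from compound 3 to compound 4 (1.52 log units; beyond the scatter). Among the compounds shown here, this is the first step at this kind of carbon with a measured number at both ends, so its size can be read directly. The earlier step with ethyl on the fluoro compound, an at least 7.6-fold lower number from compound 1 to compound 2 (0.88 log units; beyond the scatter), gives only a bound: the limit of > 300 uM in this assay, at which 1 of the 4 values shown sits.

The compounds shown leave open whether the step from ethyl to 1,2-dimethylpropyl carries over with fluoro in place of chloro. They also leave open whether a longer chain, a tert-butyl group or a cyclopentyl ring at this carbon would lower the number further or reverse the step.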